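Para substituent on the urea phenyl: chloro to methyl

The source may report more compounds than this note shows. Statements on the series, on what has been measured and on what is new or still open speak of the compounds shown alone.

Measured so far in a functional assay on MKN-45 cells (Homo sapiens) for cytotoxicity, read by MTT assay, with a stated time of 72 h; a higher number here means a weaker inhibitor, a lower number a stronger inhibitor:
compound 1, `CCN(CC)CCCNc1nc(-c2ccc(NC(=O)Nc3ccccc3)cc2)nc2ccsc12`: 980 nM
compound 2, `CCN(CC)CCCNc1nc(-c2ccc(NC(=O)Nc3ccc(Cl)cc3)cc2)nc2ccsc12`: 180 nM

Within the data shown here, only one step is measured so far, namely a 5.4-fold lower number from compound 1 to compound 2 (0.74 log units; beyond the scatter). On these two numbers compound 2 therefore stands lowest, with compound 1 as its nearest and only neighbour.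

Compound 3, `CCN(CC)CCCNc1nc(-c2ccc(NC(=O)Nc3ccc(C)cc3)cc2)nc2ccsc12`, is the next member and differs from compound 2 in one place: methyl in place of chloro on an aromatic carbon. The measured step bears on it only indirectly, as it shows that placing chloro on that aromatic carbon, para to the large group, moved the number well beyond the scatter; nothing yet measured compares methyl with chloro at that position, so the size of the new step has to be taken from the general run of such exchanges in this assay rather than from a step seen in this series.

The step expected from this change is a 1.7-fold higher number from compound 2 to compound 3 (0.22 log units; within the scatter), a modest move towards a higher number that may well stay inside the scatter. For compound 3 the estimated value is 300 nM, with an expected range from 120 nM to 800 nM.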

Compound 3, half-maximal inhibitory concentration: 1760 nM
Compound 3: middle estimate off by 5.9-fold (0.77 log units), on the low side, outside the stated range (above it).
By their numbers in this assay, from the lowest: compound 2; then compounds 1 and 3 (each within the scatter of the next).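

In this assay, the exchange of chloro for methyl on the aromatic carbon para to a large group is far from neutral, giving a 9.8-fold higher number from compound 2 to compound 3 (0.99 log units; beyond the scatter) even though each group has one heavy atom and neither has a hydrogen-bond donor or acceptor. Methyl against hydrogen at the same position gives a 1.8-fold higher number from compound 1 to compound 3 (0.25 log units; within the scatter) and so stays within the scatter, whereas chloro against hydrogen gave a 5.4-fold lower number from compound 1 to compound 2 (0.74 log units; beyond the scatter); among these three compounds, the lower number therefore belongs to chloro alone, and compound 1 and compound 3 do not separate. Nothing available explains why the two groups part so widely at this position.

On these data alone, three compounds cannot show whether chloro is a special case at this position or one member of a wider set, so it remains open whether fluoro, bromo, methoxy or trifluoromethyl would fall with chloro or with methyl. Also open, as far as these compounds go, is whether the gap between chloro and methyl keeps its size when the diethylamino chain is replaced by a shorter chain or a morpholine.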